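Swapping Chlorophenyl for Hydroxybenzyl on the Shared Core

The source may hold more compounds than are shown below. What is called first, only, known or untested is meant among the compounds shown, and "the series" means these compounds.

Going by the values given here, compound 2 `CCCSc1nc(Nc2ccc(Cl)cc2)c2nc(Nc3ccccc3)sc2n1` supplies the only true number of the pair: in a functional assay on MGC-803 cells (Homo sapiens) for antiproliferative activity, read by MTT assay, with a stated time of 72 h (a higher number here means a weaker inhibitor, a lower number a stronger inhibitor), compound 2 gives 12500 nM. Compound 1 `CCCSc1nc(NC2CC2)c2nc(Nc3ccccc3)sc2n1` returns in this assay only a limit, > 64000 nM. Among the compounds with values here, the single measured step at the nitrogen now altered is an at least 5.1-fold lower number from compound 1 to compound 2 (0.70 log units; beyond the scatter), read against the limit (the limit of > 64000 nM in this assay, at which 1 of the 2 values shown sits). Compound 3 `CCCSc1nc(NCc2ccc(O)cc2)c2nc(Nc3ccccc3)sc2n1` carries the change (4-hydroxybenzyl in place of 4-chlorophenyl on a nitrogen on an aromatic ring). Within the data shown here, with one step, starting from a limit, as the only guide, a modest rise in the number is expected, a 2.0-fold higher number from compound 2 to compound 3 (0.30 log units; within the scatter). Compound 3 is therefore estimated to give 25000 nM, with a range from 8000 nM to 80000 nM.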

Compound 3, half-maximal inhibitory concentration: 21900 nM
Estimate against measurement, compound 3: 1.1-fold (0.06 log units) above; the range from low to high includes it.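

In this assay, a 1.8-fold higher number from compound 2 to compound 3 (0.24 log units; within the scatter), so 4-hydroxybenzyl and 4-chlorophenyl on this nitrogen cannot be told apart, even though the change swaps chlorine for a hydrogen-bond donor and acceptor. Against cyclopropyl, the new group gives an at least 2.9-fold lower number from compound 1 to compound 3 (0.46 log units; beyond the scatter), so both ring-bearing groups now stand on the same side of compound 1. That step is read against a limit: the limit of > 64000 nM in this assay, at which 1 of the 3 values shown sits.

Going by these compounds, the hydroxyl and the added carbon arrive together, and their separate contributions remain open. A plain benzyl or a 4-methoxybenzyl on this nitrogen would be needed to separate them.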